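Replacing methoxyphenyl with chlorophenoxy: expected solubility step

This account rests on a few compounds, and the source may have more. Where it says the series, first, only, none or still open, it means among the compounds named here.

Compound 3 `COc1ccc(-c2ccc3c(NCCCNCc4cc(F)ccc4OC)ccnc3c2)cc1` gives 32000 nM in a physicochemical assay for solubility, with a stated time of 18 h, at pH 7.4 (on this read-out lower numbers stand for lower solubility and higher numbers for higher solubility), the highest of the three numbers shown. Compound 1 `COc1ccc(Oc2ccc3c(NCCCNCc4cc(F)ccc4OC)ccnc3c2)cc1` gives 14500 nM and compound 2 `COc1ccc(F)cc1CNCCCNc1ccnc2cc(CC(C)C)ccc12` gives 4200 nM; the steps of a 2.2-fold higher number from compound 1 to compound 3 (0.34 log units; beyond the scatter) and a 7.6-fold higher number from compound 2 to compound 3 (0.88 log units; beyond the scatter) separate both from compound 3. Compound 4 `COc1ccc(F)cc1CNCCCNc1ccnc2cc(Oc3ccc(Cl)cc3)ccc12` differs from compound 3 by 4-chlorophenoxy in place of 4-methoxyphenyl on an aromatic carbon. For the measured compounds named here, no measured step matches this change exactly. The closest guide is a 2.2-fold higher number from compound 1 to compound 3 (0.34 log units; beyond the scatter). Going by the values given here, compound 1 carries 4-methoxyphenoxy on the same aromatic carbon, whereas compound 4 carries 4-chlorophenoxy, for which no analogue has been measured. Compound 4 is therefore expected to show a modest downward step, a 4.0-fold lower number from compound 3 to compound 4 (0.60 log units; beyond the scatter). Compound 4 is estimated at 8000 nM, within the range 3000 nM to 22000 nM.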

Compound 4, solubility: 14500 nM
The estimate for compound 4 lay 1.8-fold (0.26 log units) below the measured number; the measured number falls inside the stated range.
By their numbers in this assay, from the lowest: compound 2; then compounds 1 and 4 (each within the scatter of the next); then compound 3.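

In this assay the exchange of methoxy for chloro on the phenoxy group gives no change at the digits printed from compound 1 to compound 4 (within the scatter) and so leaves the number unmoved at this position. The steps of a 2.2-fold lower number from compound 3 to compound 4 (0.34 log units; beyond the scatter) and a 3.5-fold higher number from compound 2 to compound 4 (0.54 log units; beyond the scatter) match in size those printed for compound 1, placing compound 4 level with compound 1 against both other compounds. No evidence at hand accounts for these numbers.

Going by these compounds, whether 4-chlorophenyl would stand level with compound 3 remains open. So does the outcome of an amine or a carboxylic acid in place of chloro on the phenoxy group.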